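Fluorine on a Saturated Ring Carbon of Compound 3

A few compounds are considered here, and "the series" means these few. Any claim that something is new, unique, unknown or untested is made for them only; others in the source may bear on it.

Compound 1, `C/C=C/C(=O)OCC1=CC(O)CCC1=O`: 10000 nM
Compound 2, `C/C=C/C(=O)OCC1=C[C@@H](O)[C@H](O)[C@H](F)C1=O`: > 200000 nM
Compound 3, `C/C=C/C(=O)OCC1=C[C@H]2O[C@](C)(OC)[C@@](C)(OC)O[C@@H]2CC1=O`: 60000 nM

Of the compounds shown here, three have been tested in a functional assay on NCI-H460 cells (Homo sapiens) for cytotoxicity, read by MTT assay; a lower number here means a stronger inhibitor, a higher number a weaker inhibitor. Compound 1 gives 10000 nM. Compound 2 reaches only the limit of this assay at > 200000 nM, so no number is known for it; this is the limit of > 200000 nM in this assay, at which 1 of the 3 values shown sits. Compound 3 gives 60000 nM, the higher of the two numbers that exist, and compound 1 sits at a number lower by a gap that lies beyond the usual scatter. Compound 2 differs from compound 1 and from compound 3 in several places at once, so its limit cannot be tied to any single change.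

Compound 4 `C/C=C/C(=O)OCC1=C[C@H]2O[C@](C)(OC)[C@@](C)(OC)O[C@@H]2[C@H](F)C1=O` differs from compound 3 by fluoro in place of hydrogen on a saturated ring carbon. Within the data shown here, no measured pair in this set isolates this change. Among the measured compounds shown here, still, the only compound carrying a fluorine on its ring, compound 2, sits at the limit, while the two fluorine-free compounds give numbers. On that basis compound 4 is expected to move toward a weaker number, and the estimated step is a 2.5-fold higher number from compound 3 to compound 4 (0.40 log units; beyond the scatter). Compound 4 is accordingly estimated at 150000 nM, with a range from 40000 nM to 400000 nM.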

Compound 4, half-maximal inhibitory concentration: 43000 nM
For compound 4 the middle estimate is 3.5-fold (0.54 log units) above the measured one; measured number inside the range.
By their numbers in this assay, from the lowest: compound 1; then compounds 4 and 3 (each within the scatter of the next). At a limit, above all of these: compound 2.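

In this assay, among these compounds, compound 3 and compound 4 form the first pair that isolates fluoro in place of hydrogen on a saturated ring carbon, and the result is a 1.4-fold lower number from compound 3 to compound 4 (0.14 log units; within the scatter) as the single step. At this place, next to the ring atom that bears a fused ring, the two compounds therefore cannot be told apart by this read-out. Compound 4 also shows that a fluorine on this ring carbon can stand in a compound that gives a number, so the presence of a ring fluorine no longer goes only with a limit in this series.

From the compounds shown here alone, whether a chloro group, a methyl group or an amine on the same ring carbon would also leave the read-out within the scatter stays open, as does the effect of fluoro on a core without the two methoxy-bearing carbons of compound 3. Compound 2 still gives a limit and not a number, and what sets it there stays unresolved: the limit of > 200000 nM in this assay, at which 1 of the 4 values shown sits.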